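The source may hold more compounds than are shown below. What is called first, only, known or untested is meant among the compounds shown, and "the series" means these compounds.

Measured compounds:
- compound 1 `Nc1nc(S)c2cc(S(=O)(=O)c3ccc4ccccc4c3)ccc2n1`: 7.6
- compound 2 `Cc1c(NC(=O)CCc2ccc(Cl)cc2)ccc2nc(N)nc(N)c12`: 7.48
- compound 3 `Nc1nc(N)c2c(Cl)c(NC(=O)COc3ccc4ccccc4c3)ccc2n1`: 7.85

In an assay for inhibition of Dihydrofolate reductase (Homo sapiens) (a higher number here means a more potent compound, by a factor of ten per unit of this negative logarithm, a lower number a less potent compound), compound 3 gives the highest of the three numbers. Its nearest neighbour on that scale is compound 1, whose number is lower by an amount that stays within the scatter of repeated measurements; compound 2 lies furthest away, with a number lower by an amount beyond the scatter.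

Compound 4 `Cc1c(NC(=O)COc2ccc3ccccc3c2)ccc2nc(N)nc(N)c12` has not yet been measured in this assay. It differs from compound 3 in one place: methyl in place of chloro on an aromatic carbon. Compound 2 also carries a methyl at that place on the shared core, but it differs from compound 4 in the side chain as well, so the two values cannot be separated into a contribution of the methyl alone.

Among the compounds with values here, since no step between measured compounds isolates this change, the expectation rests on the value of compound 3 in this assay, which is 7.85, and the step from there is expected to be a number 0.15 log units lower from compound 3 to compound 4 (within the scatter), small and not beyond the scatter. Compound 4 is therefore estimated at 7.7, with a range from 7.2 to 8.2.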

Compound 4, logarithm of the reciprocal of the active concentration, log(1/C): 7.82
The estimate for compound 4 lay 0.12 log units below the measured number; low and high end bracket the measured number.
By their numbers in this assay, from the lowest: compounds 2, 1, 4 and 3 (each within the scatter of the next, the first and the last beyond it).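

Within the data shown here, exchanging chloro for methyl on this aromatic carbon, ortho to a fused ring and ortho to a large group, is the first change that can be read on its own, and in this assay it amounts to a number 0.03 log units lower from compound 3 to compound 4 (within the scatter) with the side chain held fixed. Among these compounds, at this place on the shared core, the two groups therefore cannot be told apart in this assay, which the earlier compounds could not show. Nothing available explains why the two groups read alike.

Going by these compounds, whether the same holds for other groups at this place, such as an amine, a methoxy group or a plain hydrogen, remains open. On these data alone, it is also open whether chloro and methyl would read alike with the side chain of compound 2.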